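Amide to Sulfonamide: Clearance in Human Liver Microsomes

This account rests on a few compounds, and the source may have more. Where it says the series, first, only, none or still open, it means among the compounds named here.

Of the compounds shown here, three of one series have been measured in an ADME assay on microsomes from liver (Homo sapiens) for metabolic stability, read by LC-MS, using NADPH, with stated times of 10 min and 30 min; on this read-out lower numbers stand for slow clearance and higher numbers for fast clearance. Compound 1 `CC(=O)N[C@@H]1CCCc2c1cncc2N1C(=O)c2ccc(Cl)cc2[C@H]1C` is reported only as a limit of the assay, giving < 3.5 mL/min/kg in this assay. Compound 3 `CCC(=O)N[C@@H]1CCCc2c1cncc2N1C(=O)c2ccc(Cl)cc2[C@@H]1C` likewise returns a limit, not a number: in this assay compound 3 gives < 3.5 mL/min/kg. Compound 2 `CCC(=O)N[C@@H]1CCCc2c1cncc2N1CCc2cc(Cl)ccc2C1=O` stands at the same limit, giving < 3.5 mL/min/kg in this assay. For the measured compounds named here, every value shown therefore sits at the limit of < 3.5 mL/min/kg in this assay, at which 3 of the 3 values shown sit, and since no two measured compounds differ in a single place, no step between measured compounds can be read from these numbers.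

Compound 4 `CS(=O)(=O)N[C@@H]1CCCc2c1cncc2N1CCc2cc(Cl)ccc2C1=O` differs from compound 2 in one place (methylsulfonyl in place of propanoyl on an amine nitrogen). Going by the values given here, with no measured step to rest on, the expectation for the step that the limit leaves unreadable from compound 2 to compound 4 is a change no larger than the scatter, in no particular direction. Compound 4 is accordingly expected to give about 2.5 mL/min/kg in this assay, within a range from 1 mL/min/kg to 6 mL/min/kg, most likely again reported as a limit.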

Compound 4, clearance: < 3.5 mL/min/kg
Compound 4 ended at the assay's limit; the forecaster's own chance of this, stated with the estimate: 70%; the middle value lies beyond the limit too.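

Compound 2 and compound 4 are both reported only as limits in this assay and no new step can be read between them. The compounds shown leave open how fast each is actually cleared, and whether methylsulfonyl in place of propanoyl on an amine nitrogen changes clearance at all.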